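The source may hold more compounds than are shown below. What is called first, only, known or untested is meant among the compounds shown, and "the series" means these compounds.

Measured in a functional assay on the whole organism for activation, with Mus musculus as the target; on this read-out higher numbers stand for an effect only at larger amounts of compound and lower numbers for an effect already at smaller amounts:
- compound 1 `CCSc1nc(N)c2nc(O)n(Cc3ccccc3)c2n1`: 0.1 mg/kg
- compound 2 `Cc1nc(N)c2nc(O)n(Cc3ccccc3)c2n1`: 3 mg/kg
- compound 3 `Nc1ncnc2c1nc(S)n2Cc1ccccc1`: only a limit, > 30 mg/kg

Compound 1 stands lowest of the two numbers in this assay; its nearest neighbour is compound 2, reached by a 30-fold higher number from compound 1 to compound 2 (1.48 log units; beyond the scatter). Compound 3 sits at the limit of this assay and gives no number, (the limit of > 30 mg/kg in this assay, at which 1 of the 3 values shown sits).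

Compound 4 `CCOc1nc(N)c2nc(O)n(Cc3ccccc3)c2n1` is not yet measured. It differs from compound 1 in one place: ethoxy in place of ethylsulfanyl on an aromatic carbon. Within the data shown here, the only measured step that touches the same position on the shared core is a 30-fold higher number from compound 1 to compound 2 (1.48 log units; beyond the scatter), a large step that replaced the ethylsulfanyl group by a single-atom methyl. The change to compound 4 is of another kind: ethoxy carries the same count of heavy atoms and the same count of hydrogen-bond acceptors as the ethylsulfanyl it replaces, so the two-carbon chain at that position is kept. Among the measured compounds shown here, compound 3, which lacks any substituent at that position of its core, offers no step that can be drawn on here.

A step in this assay toward higher numbers is expected, but well short of the large step seen toward compound 2. Compound 4 is therefore estimated at 0.3 mg/kg, within 0.1 mg/kg to 1 mg/kg, which means an expected step of a 3.0-fold higher number from compound 1 to compound 4 (0.48 log units; beyond the scatter).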

Compound 4, minimum effective dose: 0.3 mg/kg
Compound 4: the middle estimate sits on the measured number at the digits printed; low and high end bracket the measured number.
By their numbers in this assay, from the lowest: compound 1; then compound 4; then compound 2. At a limit, above all of these: compound 3.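

In this assay, swapping ethylsulfanyl for ethoxy on the aromatic carbon between two ring nitrogen atoms gives a 3.0-fold higher number from compound 1 to compound 4 (0.48 log units; beyond the scatter) in a change that leaves the heavy-atom and hydrogen-bond acceptor counts as they were, so the number at this position responds to more than those counts. Set against methyl at the same carbon, ethoxy gives a 10-fold lower number from compound 2 to compound 4 (1.00 log units; beyond the scatter) and so keeps most of the gap that separates ethylsulfanyl from methyl, which means the low numbers across these three compounds are not confined to the sulfur-bearing group. Nothing measured here speaks to the reason for either step.

Open questions remain on how far the chain at this carbon can change, as a longer chain such as butoxy or butylsulfanyl, or an amine such as ethylamino, would test whether the order of ethylsulfanyl, ethoxy and methyl extends beyond these groups. As far as these compounds go, the benzyl group and the amino group are the same in all three compounds, so it also remains open whether the step between ethylsulfanyl and ethoxy would keep its size with a different group in either place.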